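Lipophilicity notes: naphthyloxy acetohydrazones, bromo to nitro

The source may hold more compounds than are shown below. What is called first, only, known or untested is meant among the compounds shown, and "the series" means these compounds.

Measured so far:
compound 1 `O=C(COc1cccc2ccccc12)N/N=C/c1ccc(Cl)cc1`, 4.54
compound 2 `O=C(COc1cccc2ccccc12)N/N=C/c1ccc(O)cc1`, 3.73
compound 3 `O=C(COc1cccc2ccccc12)N/N=C/c1ccc(Br)cc1`, 4.81

In a physicochemical assay for lipophilicity, measured as octanol-water partition (a higher number here means a more lipophilic compound, a lower number a more polar compound), compound 3 stands highest of the three numbers. Its nearest neighbour is compound 1: the step of a number 0.27 log units higher from compound 1 to compound 3 (within the scatter) is within the scatter, so no order between the two can be claimed. Its furthest neighbour is compound 2, with a number 1.08 log units higher from compound 2 to compound 3 (beyond the scatter) beyond the scatter.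

Compound 4 `O=C(COc1cccc2ccccc12)N/N=C/c1ccc([N+](=O)[O-])cc1` is not yet measured in this assay. It differs from compound 3 in one place: nitro in place of bromo on an aromatic carbon.

For the measured compounds named here, two measured steps bear on this change, both exchanging a halogen for a group that is not a halogen: a number 0.81 log units lower from compound 1 to compound 2 (beyond the scatter) and, in the opposite direction, a number 1.08 log units higher from compound 2 to compound 3 (beyond the scatter). The halogen-for-halogen exchange a number 0.27 log units higher from compound 1 to compound 3 (within the scatter) is within the scatter and says little here. A downward step in this assay, beyond the scatter, is therefore expected from compound 3 to compound 4, though a nitro group is not a hydroxy group, so the exact size is uncertain.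

For compound 4 the expected value in this assay is 3.95, with a range of 3.5 to 4.4, an estimated step of a number 0.86 log units lower from compound 3 to compound 4 (beyond the scatter).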

Compound 4, partition coefficient: 3.97
Compound 4: middle estimate off by 0.02 log units, on the low side; low and high end bracket the measured number.
By their numbers in this assay, from the lowest: compounds 2 and 4 (each within the scatter of the next); then compounds 1 and 3 (each within the scatter of the next).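

In this assay, nitro in place of bromo on this aromatic carbon gives a number 0.84 log units lower from compound 3 to compound 4 (beyond the scatter) and nitro in place of chloro gives a number 0.57 log units lower from compound 1 to compound 4 (beyond the scatter), so a second non-halogen group now stands clearly apart from both halogens. Nitro and hydroxy cannot be separated here, with a number 0.24 log units higher from compound 2 to compound 4 (within the scatter) as the step between them, and the four compounds therefore form two groups, compounds 2 and 4 on one side and compounds 1 and 3 on the other, a split claimed for these four only. The step from compound 3 to compound 4 also brings in more heavy atoms, with nitro holding 3 where bromo holds 1, and the number still goes down, so heavy-atom count alone does not order this change; no measurement at hand explains the split.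

Going by these compounds, whether an amine, a methoxy group or a carboxylic acid at the same place would fall with compounds 2 and 4, with compounds 1 and 3, or apart from both remains open. Also open is whether the nitro step keeps its size at another place on this ring or on a different core, as all the compounds shown share one core and vary at one place.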